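The source may report more compounds than this note shows. Statements on the series, on what has been measured and on what is new or still open speak of the compounds shown alone.

Compound 1 `NS(=O)(=O)c1ccc(C(=O)N/N=C\c2ccc(Br)cc2)cc1` and compound 2 `NS(=O)(=O)c1ccc(C(=O)N/N=C\c2ccc(Cl)cc2)cc1` share one core. In a functional assay on MCF7 cells (Homo sapiens) for antiproliferative activity, read by MTT assay (a higher number here means a weaker inhibitor, a lower number a stronger inhibitor), compound 1 gives 1370 nM, while compound 2 gives 36700 nM. Within the data shown here, the only change between them, (chloro in place of bromo on an aromatic carbon), produced a 27-fold higher number from compound 1 to compound 2 (1.43 log units; beyond the scatter). Compound 3 `NS(=O)(=O)c1ccc(N/N=C(/CS(=O)(=O)c2ccccc2)c2ccc(Br)cc2)cc1` is built on a different core, and the difference between the two cores is not broken down here. In this assay compound 3 gives 17300 nM. Compound 4 `NS(=O)(=O)c1ccc(N/N=C(/CS(=O)(=O)c2ccccc2)c2ccc(Cl)cc2)cc1` differs from compound 3 by chloro in place of bromo on an aromatic carbon, the same change, at a place described in the same words, so the change appears in both pairs. Because compound 3 gives 17300 nM and the earlier step was a 27-fold higher number from compound 1 to compound 2 (1.43 log units; beyond the scatter), a weaker but still upward step is expected for compound 4, namely a 4.6-fold higher number from compound 3 to compound 4 (0.67 log units; beyond the scatter), since a single earlier pair on another core is a thin basis. Compound 4 is therefore estimated at 80000 nM, plausibly between 17000 nM and 400000 nM.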

Compound 4, half-maximal inhibitory concentration: 8010 nM
The estimate for compound 4 lay 10-fold (1.00 log units) above the measured number, and the stated range ends above it.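

Putting chloro in place of bromo on the core of compound 3 gave a 2.2-fold lower number from compound 3 to compound 4 (0.33 log units; beyond the scatter) in this assay. The same change therefore did not carry over from one core to the other, in either size or direction: the same change on two cores in this assay, a 27-fold higher number (1.43 log units; beyond the scatter) from compound 1 to compound 2 and a 2.2-fold lower number (0.33 log units; beyond the scatter) from compound 3 to compound 4, 58-fold (1.76 log units) apart, beyond the scatter of two such steps

These two pairs show that the result of this swap depends on the core it sits on, but they do not show which part of the core is responsible or how the swap would behave on a further core. The compounds shown hold only bromo or chloro at this place, which leaves open how fluoro, methyl or an amine there would read on either core. Going by these compounds, with a single pair on each core, it also remains open whether other groups would differ between the cores in the same way.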